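The source may hold more compounds than are shown below. What is called first, only, known or untested is meant among the compounds shown, and "the series" means these compounds.

Compound 1, `Cc1ccc(NC(=O)CSc2nccn2-c2cccc3ccccc23)c(Br)c1`, in an ADME assay on MT4 cells (Homo sapiens) for cytotoxicity, read by MTT assay (a lower number here means that less compound is tolerated, a higher number that more compound is tolerated), gives 29400 nM.
Compound 2, `O=C(CSc1nccn1-c1ccc(Cl)cc1)Nc1ccccc1F`, in this assay shows only > 345000 nM, which is a limit of the assay rather than a number.

Compound 2 thus stands at the limit itself: of the two values shown, one sits at it (the limit of > 345000 nM in this assay, at which 1 of the 2 values shown sits), and compound 2 is that one. Its true value is not known, only that it lies beyond what the assay could report. Compound 3, `O=C(CSc1nccn1-c1ccc(Cl)cc1)Nc1ccccc1Br`, has not yet been measured in this assay. It differs from compound 2 in one place: bromo in place of fluoro on an aromatic carbon. Among the measured compounds shown here, no measured pair shows this same exchange on its own, so the size of the step cannot be read from the data. Compound 1 also bears a bromo group, but it differs from compound 2 in several other places as well, so its value says little about this exchange alone. The expectation is a step from compound 2 to compound 3 of an at least 1.3-fold lower number from compound 2 to compound 3 (0.13 log units; that floor lies within the scatter), small and within the scatter. Compound 3 is therefore estimated at 250000 nM, within 70000 nM to 500000 nM, with a fair chance that the assay again reports only a limit.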

Compound 3, half-maximal cytotoxic concentration: > 300000 nM
Compound 3: a limit, no number (the forecaster's own chance of this, stated with the estimate: 50%); middle value at least 1.2-fold (0.07 log units) away from the limit.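

Compound 2 and compound 3 each give only a limit in this assay, not a number, and no step can be read between them for bromo in place of fluoro. The compounds shown leave open whether this exchange changes the tolerated concentration at all, and how far the true value of either compound lies beyond its limit.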